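Sigma receptor binding: swapping the amine at the chain end

This account rests on a few compounds, and the source may have more. Where it says the series, first, only, none or still open, it means among the compounds named here.

Compound 2, `O=c1cc(-c2ccccc2)oc2ccc(OCCCCCCN3CCCC(O)C3)cc12`: 86 nM in an assay on isolated protein (Cavia porcellus) with Sigma non-opioid intracellular receptor 1 (Homo sapiens) as the target, read by radioligand binding; a lower number here means a stronger inhibitor, a higher number a weaker inhibitor
Compound 1, `CN(C)CCCCCCCCCOc1ccc2oc(-c3ccccc3)cc(=O)c2c1`: 334 nM in this assay

Compound 2 stands lowest of the two numbers, and the step of a 3.9-fold lower number from compound 1 to compound 2 (0.59 log units; beyond the scatter) lies beyond the scatter. Compound 3, `CN(CCCCCCOc1ccc2oc(-c3ccccc3)cc(=O)c2c1)Cc1ccccc1`, has not been measured. It differs from compound 2 by benzyl(methyl)amino in place of 3-hydroxypiperidin-1-yl on a saturated chain carbon, six bonds along the chain from an oxygen on an aromatic ring. Among the measured compounds shown here, the one measured step changes a different pair of groups at this position, so it bears only loosely; nothing shows what the benzyl(methyl)amino group does here. A change near the scatter is therefore expected, a 1.4-fold lower number from compound 2 to compound 3 (0.16 log units; within the scatter), and compound 3 is estimated at 60 nM, within 15 nM to 250 nM.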

Compound 3, half-maximal inhibitory concentration: 52 nM
The estimate for compound 3 lay 1.2-fold (0.06 log units) above the measured number, within the range that was stated.
By their numbers in this assay, from the lowest: compounds 3 and 2 (each within the scatter of the next); then compound 1.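

In this assay, benzyl(methyl)amino in place of 3-hydroxypiperidin-1-yl gives a 1.7-fold lower number from compound 2 to compound 3 (0.22 log units; within the scatter), so on this chain carbon a hydroxyl-bearing saturated ring and a carbon-only aromatic ring give numbers that cannot be told apart. The larger step, a 6.4-fold lower number from compound 1 to compound 3 (0.81 log units; beyond the scatter), shows that benzyl(methyl)amino, like 3-hydroxypiperidin-1-yl, stands clear of the 3-(dimethylamino)propyl end. Open still is how a morpholine or a piperazine would fare at this chain carbon, and whether a methoxy group on the benzyl ring would move the number. No supporting evidence explains these steps.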